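Swapping a hydroxymethyl for a hydroxy on a furan-bearing core

The source may hold more compounds than are shown below. What is called first, only, known or untested is meant among the compounds shown, and "the series" means these compounds.

Of the compounds shown here, two sharing one core have been measured in an assay on CHO cells for displacement of a labelled ligand from adenosine receptor A3 (Homo sapiens), read by scintillation counting, with a stated time of 3 h; on this read-out higher numbers stand for weaker inhibition and lower numbers for stronger inhibition. Compound 1 `Nc1nc(-c2cccc(O)c2)nc2sc(-c3ccccc3)nc12` carries a hydroxy group on its pendant six-membered ring and a phenyl group on the other side of the core; in this assay compound 1 gives 190 nM. Compound 2 `Nc1nc(-c2cccc(CO)c2)nc2sc(-c3ccco3)nc12` carries a hydroxymethyl group on the six-membered ring and a furan ring in place of the phenyl; in this assay compound 2 gives 0.9 nM. Of the two numbers, that of compound 2 is the lower, and the gap to compound 1 lies beyond the usual scatter. The two compounds differ in two places at once, so the numbers alone do not show which change carries the difference.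

Compound 3 `Nc1nc(-c2cccc(O)c2)nc2sc(-c3ccco3)nc12` keeps the furan ring of compound 2 and changes only the six-membered ring: hydroxy in place of hydroxymethyl on an aromatic carbon. Going by the values given here, no measured pair shows this change on its own. Compound 1, which also carries a hydroxy group, gives a much higher number, yet it differs in the second place too. The step from compound 2 to compound 3 is expected to be a moderate weakening, a 4.4-fold higher number from compound 2 to compound 3 (0.65 log units; beyond the scatter). Compound 3 is therefore estimated to give 4 nM in this assay, with a likely range from 0.8 nM to 30 nM.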

Compound 3, inhibition constant: 15.7 nM
Beside the measured number, compound 3's estimate is 3.9-fold (0.59 log units) below it; measured number inside the range.
By their numbers in this assay, from the lowest: compound 2; then compound 3; then compound 1.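

In this assay, with the furan ring held constant, hydroxy in place of hydroxymethyl on an aromatic carbon gives a 17-fold higher number from compound 2 to compound 3 (1.24 log units; beyond the scatter) and so shows that this group alone has a large effect on the number. With the hydroxy group held constant, furan-2-yl in place of phenyl gives a 12-fold lower number from compound 1 to compound 3 (1.08 log units; beyond the scatter) and so shows that the other place also matters, which means that the wide gap between compound 1 and compound 2 does not come from one change alone. Nothing available explains why either step has the size it does.

The compounds shown leave open how a longer chain such as hydroxyethyl, or an aminomethyl or methoxy group, would read at this place on the six-membered ring, and so whether the low number of compound 2 is specific to hydroxymethyl. They also leave open whether hydroxymethyl would lower the number to a similar extent on the core of compound 1, where phenyl stands in place of the furan ring.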